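A few compounds are considered here, and "the series" means these few. Any claim that something is new, unique, unknown or untested is made for them only; others in the source may bear on it.

Measured so far in an ADME assay on HepG2 cells (Homo sapiens) for cytotoxicity, in the presence of a further agent that is not named here; a lower number here means a stronger inhibitor, a higher number a weaker inhibitor:

- Compound 1 `Cn1c(Cc2ccccc2C(F)(F)F)nc(C(=O)NCc2cccnc2)c(O)c1=O`: > 100000 nM (a limit)
- Compound 2 `CN(Cc1ccccc1)C(=O)c1nc(Cc2ccccc2C(F)(F)F)n(C)c(=O)c1O`: > 100000 nM (a limit)
- Compound 3 `CC(NC(=O)c1nc(Cc2ccccc2C(F)(F)F)n(C)c(=O)c1O)c1ccccc1`: > 100000 nM (a limit)

Compound 3 gives > 100000 nM, which is a limit and not a number. Compound 1 and compound 2 also report only limits, so the whole set rests on (the limit of > 100000 nM in this assay, at which 3 of the 3 values shown sit).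

Compound 4 `Cn1c(Cc2ccccc2C(F)(F)F)nc(C(=O)CCc2ccccc2)c(O)c1=O` differs from compound 3 in one place: phenethyl in place of (1-phenylethyl)amino on a carbonyl carbon. In words, this is phenethyl in place of (1-phenylethyl)amino on a carbonyl carbon.

Three measured steps alter the group at this same carbonyl carbon: a step that the two limits leave unreadable from compound 1 to compound 2, a step that the two limits leave unreadable from compound 1 to compound 3 and a step that the two limits leave unreadable from compound 2 to compound 3. None of them has a readable size, so they offer no number to carry over to the new change. Among the measured compounds shown here, they show only that compound 1, compound 2 and compound 3 all ended at a limit in this assay.

On that basis, no step beyond the scatter is expected, and no direction can be given. The expected change is a number no higher from compound 3 to compound 4 (the limit leaves the size open). A report of a limit is the likeliest result for compound 4. For compound 4 the estimated value is 100000 nM, with an expected range from 50000 nM to 200000 nM.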

Compound 4, half-maximal inhibitory concentration: > 100000 nM
Compound 4: no number, only a limit; the forecaster's own chance of this, stated with the estimate: 85%; the middle value sits exactly at the limit.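

In this assay compound 4 gives > 100000 nM, which is a limit and not a number. Among the compounds shown here, compound 1, compound 2 and compound 3 also report only limits, so no step to compound 4 can be read. The whole set rests on a single ceiling: the limit of > 100000 nM in this assay, at which 4 of the 4 values shown sit. The compounds shown leave open how their cytotoxicity compares, and whether changing the group on the carbonyl carbon matters at all.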